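Replacing chloro with a sulfamoylphenylamino group in a cytotoxicity series

A few compounds are considered here, and "the series" means these few. Any claim that something is new, unique, unknown or untested is made for them only; others in the source may bear on it.

Measured so far:
compound 1 `CCc1cccc(-c2nn3c(c2-c2ccnc(Cl)c2)C(C)C(C)(C)C3)n1`: > 100000 nM
compound 2 `CC1(C)Cc2c(-c3ccncc3)c(-c3ccccn3)nn2C1`: > 100000 nM

In a functional assay on MCF7 cells (Homo sapiens) for cytotoxicity, with a stated time of 72 h (on this read-out lower numbers stand for stronger inhibition and higher numbers for weaker inhibition), compound 1 gives only > 100000 nM, a limit of the assay and not a number. Compound 2 likewise returns > 100000 nM, also a limit. Compound 1 therefore stands at the limit of > 100000 nM in this assay, at which 2 of the 2 values shown sit, with no numbered value anywhere to set it against. Compound 3 `CCc1cccc(-c2nn3c(c2-c2ccnc(Nc4ccc(S(N)(=O)=O)cc4)c2)C(C)C(C)(C)C3)n1` differs from compound 1 by (4-sulfamoylphenyl)amino in place of chloro on an aromatic carbon. For the measured compounds named here, no measured pair differs in a single place, so no step size is known in this assay. A step toward stronger inhibition, beyond the usual scatter, is expected, an at least 20-fold lower number from compound 1 to compound 3 (1.30 log units; beyond the scatter). Compound 3 is estimated at 5000 nM, within 500 nM to 100000 nM.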

Compound 3, half-maximal inhibitory concentration: 28000 nM
Beside the measured number, compound 3's estimate is 5.6-fold (0.75 log units) below it, and the stated range covers the measured number.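

In this assay, the position next to the ring nitrogen accepts (4-sulfamoylphenyl)amino in place of chloro, and this single change gives an at least 3.5-fold lower number from compound 1 to compound 3 (0.55 log units; beyond the scatter). For the compounds shown here, compound 3 thereby supplies the only numbered value so far. The step remains a bound, not an exact size, because compound 1 gives only a limit of the assay: the limit of > 100000 nM in this assay, at which 2 of the 3 values shown sit.

Which part of the entering group carries the step stays open. A plain phenylamino group, or a carboxylic acid in place of the sulfamoyl group, would help separate the ring, the amino link and the sulfonamide.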